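Notes: 1,3-benzothiazol-5-yl in place of pyridin-4-yl

The source may hold more compounds than are shown below. What is called first, only, known or untested is meant among the compounds shown, and "the series" means these compounds.

Measured in a physicochemical assay for solubility, in phosphate buffer, at pH 7.4; on this read-out higher numbers stand for higher solubility and lower numbers for lower solubility:
- compound 1 `COCC1CCN(c2nccnc2OC2CN(c3ccc4ccccc4n3)C2)CC1` gives 53000 nM
- compound 2 `c1ccc(-c2nccnc2OC2CN(c3ccc4ccccc4n3)C2)nc1` gives 349000 nM
- compound 3 `c1ccc2nc(N3CC(Oc4nccnc4-c4ccncc4)C3)ccc2c1` gives 56000 nM

Compound 3 stands in the lower pair of these three numbers. The data show a 1.1-fold higher number from compound 1 to compound 3 (0.02 log units; within the scatter) and a 6.2-fold lower number from compound 2 to compound 3 (0.79 log units; beyond the scatter), so only compound 2 separates from the rest.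

The next structure is compound 4 `c1ccc2nc(N3CC(Oc4nccnc4-c4ccc5scnc5c4)C3)ccc2c1`, with 1,3-benzothiazol-5-yl in place of pyridin-4-yl on an aromatic carbon.

All three measured steps exchange the group at this same place. The third is a 6.6-fold higher number from compound 1 to compound 2 (0.82 log units; beyond the scatter), so two of the steps are modest and one stays within the scatter. Going by the values given here, no measured compound carries a two-ring aromatic group here, which leaves no direct precedent. Compound 1, with 4-(methoxymethyl)piperidin-1-yl at this place, gives 53000 nM, so a larger group need not bring a lower number in this assay. A modest step downward is still expected, similar in size to a 6.2-fold lower number from compound 2 to compound 3 (0.79 log units; beyond the scatter), though the direction is uncertain. The estimated change is a 4.7-fold lower number from compound 3 to compound 4 (0.67 log units; beyond the scatter). Compound 4 is expected at about 12000 nM, with an estimated range from 2500 nM to 50000 nM.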

Compound 4, solubility: < 1000 nM
Compound 4: a limit, no number (the forecaster's own chance of this, stated with the estimate: 10%); middle value at least 12-fold (1.07 log units) away from the limit.
By their numbers in this assay, from the lowest: compounds 1 and 3 (each within the scatter of the next); then compound 2. At a limit, below all of these: compound 4.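

In this assay compound 4 gives < 1000 nM, which is a limit of the assay and not a number, and it is the only such value in the set: the limit of < 1000 nM in this assay, at which 1 of the 4 values shown sits.

Exchanging pyridin-4-yl for 1,3-benzothiazol-5-yl gives an at least 56-fold lower number from compound 3 to compound 4 (1.74 log units; beyond the scatter), and the same group set against the two other groups at this place gives an at least 340-fold lower number from compound 2 to compound 4 (2.54 log units; beyond the scatter) and an at least 53-fold lower number from compound 1 to compound 4 (1.72 log units; beyond the scatter). Going by these compounds alone, these are the first large steps at this place, where the earlier exchanges were modest or within the scatter, so the aromatic carbon of the six-membered ring with 2 nitrogen tolerates some exchanges with little change in this read-out, yet it can also give a far lower number with the one group here that has a five-membered and a six-membered aromatic ring.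

The limit leaves the true size of these steps unread, and a single group cannot separate the contribution of the second ring from that of the sulfur. From the compounds shown here alone, whether a naphthyl group, with two rings and no sulfur, a plain phenyl, or a pyridine carrying an amine or a carboxylic acid would stay closer to the pyridinyl compounds remains open.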